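Butyl for 3-fluorophenyl: a side-chain step in the series

This account rests on a few compounds, and the source may have more. Where it says the series, first, only, none or still open, it means among the compounds named here.

Within the data shown here, in a functional assay on a cell-free system (plasma, Homo sapiens), with a stated time of 3 min (on this read-out higher numbers stand for weaker inhibition and lower numbers for stronger inhibition), compound 1 (`O=C(NCc1cc(Cl)ccc1-n1cnnn1)[C@@H]1C[C@H]2C[C@H]2N1C(=O)[C@H](O)CC1CC1`) gives 850 nM and compound 2 (`O=C(NCc1cc(Cl)ccc1-n1cnnn1)[C@@H]1C[C@H]2C[C@H]2N1C(=O)[C@H](O)c1cccc(F)c1`) gives 1100 nM, so compound 2 stands within the scatter of the only other number available. Compound 3 (`CCCC[C@@H](O)C(=O)N1[C@@H]2C[C@@H]2C[C@H]1C(=O)NCc1cc(Cl)ccc1-n1cnnn1`) carries butyl in place of 3-fluorophenyl on a saturated chain carbon bound to a carbonyl carbon and an oxygen on a saturated carbon, with butyl in place of 3-fluorophenyl on a saturated chain carbon bound to a carbonyl carbon and an oxygen on a saturated carbon. Among the measured compounds shown here, the one measured step at that place, a 1.3-fold higher number from compound 1 to compound 2 (0.11 log units; within the scatter), put 3-fluorophenyl in place of cyclopropylmethyl and stayed within the scatter. On that single step, no change beyond the scatter is expected in this assay. The expected step is a 1.2-fold lower number from compound 2 to compound 3 (0.09 log units; within the scatter). The estimate for compound 3 is 900 nM, with an expected range of 400 nM to 2000 nM.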

Compound 3, half-maximal inhibitory concentration: 870 nM
Beside the measured number, compound 3's estimate is 1.0-fold (0.01 log units) above it, and the stated range covers the measured number.
By their numbers in this assay, from the lowest: compounds 1, 3 and 2 (each within the scatter of the next).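

At the saturated chain carbon bound to a carbonyl carbon and an oxygen on a saturated carbon, butyl adds an open chain with no ring, and in this assay it stays within the scatter of both neighbours (a 1.3-fold lower number from compound 2 to compound 3 (0.10 log units; within the scatter)) (a 1.0-fold higher number from compound 1 to compound 3 (0.01 log units; within the scatter)). Across these three compounds, butyl, cyclopropylmethyl and 3-fluorophenyl therefore cannot be told apart at this place. No available evidence bears on this result.

Still open, going by these compounds, is whether an amine or a carboxylic acid at this place would give a step beyond the scatter. A longer chain poses the same question.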